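The source may hold more compounds than are shown below. What is called first, only, known or untested is meant among the compounds shown, and "the series" means these compounds.

Measured so far:
- compound 1 `CN(C)C(=O)c1cc2cnc(Nc3ccc(NC(=O)C4(C(=O)Nc5ccc(Cl)cc5)CC4)cc3)nc2n1C1CCCC1` gives 21.3% in a functional assay on NCI-H460 cells (Homo sapiens) for inhibition, read by CCK-8 assay, with a stated time of 72 h, tested at 1 uM; a higher number here means more inhibition of growth at the concentration tested, a lower number less inhibition of growth
- compound 2 `CN(C)C(=O)c1cc2cnc(Nc3ccc(NC(=O)C4(C(=O)Nc5cccc(Cl)c5)CC4)cc3)nc2n1C1CCCC1` gives 44% in this assay

Among the compounds with values here, compound 2 stands highest of the two numbers in this assay; the nearest is compound 1, and the one step between them, a number 22.7 percentage points higher from compound 1 to compound 2 (beyond the scatter), lies beyond the scatter. Compound 3 `CN(C)C(=O)c1cc2cnc(Nc3ccc(NC(=O)C4(C(=O)Nc5ccccc5)CC4)cc3)nc2n1C1CCCC1` is not yet measured. It differs from compound 2 by hydrogen in place of chloro on an aromatic carbon.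

Within the data shown here, no measured step removes the chloro; the only step available, a number 22.7 percentage points higher from compound 1 to compound 2 (beyond the scatter), moves it from one position to another on the same ring and is therefore only indirect support. Since compound 2 carries the chloro on the position that gave the higher number, taking it away is expected to cost some inhibition, though the size is uncertain and a result within the scatter is possible. The step of a number 14 percentage points lower from compound 2 to compound 3 (beyond the scatter) is the expected outcome. Compound 3 is estimated at 30%, within 10% to 52%.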

Compound 3, percent growth inhibition at one concentration: 42.4%
Beside the measured number, compound 3's estimate is 12.4 percentage points below it; low and high end bracket the measured number.
By their numbers in this assay, from the lowest: compound 1; then compounds 3 and 2 (each within the scatter of the next).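

Taking the chloro off the 3-chlorophenyl leaves no readable change in this assay (a number 1.6 percentage points lower from compound 2 to compound 3 (within the scatter)), so this chloro is not needed for the growth inhibition seen at this concentration. The parent phenyl also reads clearly above the 4-chlorophenyl (a number 21.1 percentage points higher from compound 1 to compound 3 (beyond the scatter)), which recasts the earlier gap between the two chloro isomers: the 4-chlorophenyl compound is the one that stands apart, while the 3-chlorophenyl and phenyl compounds do not separate. No supporting data bear on why this pattern appears.

On these data alone, it remains open whether the lower number follows chloro alone or any group in that place, such as the fluoro of 4-fluorophenyl or the methoxy of 4-methoxyphenyl. As far as these compounds go, it is equally open whether 3-methoxyphenyl or a 3-carboxyphenyl, bearing a carboxylic acid, would also match the phenyl compound.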